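From isopropyl to vinyl on a carbonyl carbon

The source may report more compounds than this note shows. Statements on the series, on what has been measured and on what is new or still open speak of the compounds shown alone.

Values so far in a functional assay on BGC-823 cells (Homo sapiens) for inhibition, read by MTT assay, with a stated time of 72 h; on this read-out higher numbers stand for weaker inhibition and lower numbers for stronger inhibition
- compound 1 `O=C1Nc2ccccc2/C1=C\C(=O)c1cc(F)cc(F)c1` gives 15700 nM
- compound 2 `CC(C)C(=O)Nc1cccc(C(=O)/C=C2/C(=O)Nc3ccccc32)c1` gives 6200 nM
- compound 3 `O=C1Nc2ccccc2/C1=C\C(=O)c1ccccc1F` gives 11800 nM

In this assay compound 2 (6200 nM) cannot be told apart from compound 3 (11800 nM), since the two lie within the usual scatter of repeated measurements. Compound 2 does stand clear of compound 1 (15700 nM), whose higher number marks weaker inhibition beyond the scatter.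

The next compound, compound 4 `C=CC(=O)Nc1cccc(C(=O)/C=C2/C(=O)Nc3ccccc32)c1`, has vinyl in place of isopropyl on a carbonyl carbon and keeps the rest of compound 2 unchanged. Within the data shown here, no pair of measured compounds differs at this place, so the data give no direct guide to this change. The starting point is therefore compound 2 (6200 nM) and the narrow spread of the three values. The expected 1.4-fold lower number from compound 2 to compound 4 (0.14 log units; within the scatter) is small, leans toward a lower number and may well stay within the scatter. The estimated value for compound 4 is 4500 nM (expected range 1500 nM to 13000 nM).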

Compound 4, half-maximal inhibitory concentration: 3600 nM
Compound 4: middle estimate off by 1.3-fold (0.10 log units), on the high side; measured number inside the range.
By their numbers in this assay, from the lowest: compounds 4, 2, 3 and 1 (each within the scatter of the next, the first and the last beyond it).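

Among these compounds, this is the first pair of compounds that differ only at this place, on a carbonyl carbon whose other neighbour is an amide-type nitrogen. In this assay, vinyl in place of isopropyl gives a 1.7-fold lower number from compound 2 to compound 4 (0.24 log units; within the scatter), so the two groups cannot be told apart on this read-out, and the double bond that vinyl brings produces no clear shift here. No other measurement shown bears on what lies behind this result.

A single swap between two small carbon groups cannot show how much this position accepts, so a longer chain, a phenyl ring or an amine on the same carbonyl carbon might still move the number beyond the scatter. An ethyl group there, which has no double bond, would test whether that double bond matters at all.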